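The source may hold more compounds than are shown below. What is called first, only, known or untested is meant among the compounds shown, and "the series" means these compounds.

In a functional assay on CCRF-CEM cells (Homo sapiens) for antiproliferative activity, read by fluorescence and resazurin assay, with a stated time of 48 h (a higher number here means a weaker inhibitor, a lower number a stronger inhibitor), compound 1 `O=C(N/N=C/c1ccncc1)c1cc2cc(Br)ccc2oc1=O` gives 6340 nM and compound 3 `O=C(N/N=C/c1cc2ccccc2nc1Cl)c1cc2cc(Br)ccc2oc1=O` gives 7450 nM, while compound 2 `CCOc1ccc(NC(=O)c2cc3cc(Br)ccc3oc2=O)cc1` gives 21800 nM, the highest number of the three. Its distances to both compound 1 and compound 3 lie beyond the scatter, so compound 2 is the weakest inhibitor of the measured set. Compound 4 `CCOc1ccc(NC(=O)c2cc3ccccc3oc2=O)cc1` has not yet been measured in this assay. It differs from compound 2 in one place: hydrogen in place of bromo on an aromatic carbon. For the measured compounds named here, no measured pair shows this change, so its size cannot be read from the data. The expected step of a 1.4-fold higher number from compound 2 to compound 4 (0.14 log units; within the scatter) is small, a slight weakening that may not exceed the scatter. Compound 4 is therefore expected to give 30000 nM in this assay, within a range from 10000 nM to 80000 nM.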

Compound 4, half-maximal inhibitory concentration: 17900 nM
Compound 4: middle estimate off by 1.7-fold (0.22 log units), on the high side, within the range that was stated.
By their numbers in this assay, from the lowest: compounds 1 and 3 (each within the scatter of the next); then compounds 4 and 2 (each within the scatter of the next).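

With the ethoxyphenyl amide side chain of compound 2 held constant, hydrogen in place of bromo on this aromatic carbon gives a 1.2-fold lower number from compound 2 to compound 4 (0.09 log units; within the scatter) in this assay. This pair therefore shows no difference beyond the scatter, so the bromo is not required at this position for the activity seen in compound 2. No other data on this pair are available to explain the result.

Open, as far as these compounds go, is whether an amine or a methoxy group at this aromatic carbon would read differently from hydrogen and bromo. For the compounds shown here, also open is whether the same change would read alike in compound 1 and compound 3, which both carry the bromo and have no hydrogen counterpart here.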